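Permeability of a Quinoline Series with a Swapped Side Group

This account rests on a few compounds, and the source may have more. Where it says the series, first, only, none or still open, it means among the compounds named here.

Measured compounds:
Compound 1, `CCC(CC)c1ccc2c(NCCCNCc3cc(F)ccc3OC)ccnc2c1`: 23 10^-6 cm/s
Compound 2, `COc1ccc(F)cc1CNCCCNc1ccnc2cc(Oc3ccc(C(C)(C)C)cc3)ccc12`: 317 10^-6 cm/s
Compound 3, `CCC(CC)c1ccc2c(NCCCNCc3cccc(OC)c3O)ccnc2c1`: 23 10^-6 cm/s

All three were run in an ADME assay for permeability, using PAMPA, with a stated time of 30 min, at pH 7.4; on this read-out higher numbers stand for higher permeability and lower numbers for lower permeability. Compound 1 and compound 2 differ in one place, (4-(tert-butyl)phenoxy in place of pentan-3-yl on an aromatic carbon), and the step there is a 14-fold higher number from compound 1 to compound 2 (1.14 log units; beyond the scatter). Compound 3 shares the core of compound 1; the two differ in the side group, (2-hydroxy-3-methoxyphenyl in place of 5-fluoro-2-methoxyphenyl on a saturated chain carbon bound to an amine nitrogen), and the step is no change at the digits printed from compound 1 to compound 3 (within the scatter), so these two read as equal in this assay.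

Compound 4, `COc1cccc(CNCCCNc2ccnc3cc(Oc4ccc(C(C)(C)C)cc4)ccc23)c1O`, is not yet measured. It stands to compound 3 as compound 2 stands to compound 1: the change is 4-(tert-butyl)phenoxy in place of pentan-3-yl on an aromatic carbon, at the same place as before, so it is the same change seen once already, on the core carried by compound 3 rather than compound 1.

Among the compounds with values here, with compound 3 level with compound 1, the earlier step is the only guide. Compound 4 is expected to show a step of about a 13-fold higher number from compound 3 to compound 4 (1.12 log units; beyond the scatter), because that change gave a 14-fold higher number from compound 1 to compound 2 (1.14 log units; beyond the scatter). The estimate for compound 4 in this assay is 300 10^-6 cm/s, with a likely range from 110 10^-6 cm/s to 650 10^-6 cm/s.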

Compound 4, apparent permeability in the ADME assay: 317 10^-6 cm/s
Compound 4: the middle estimate sits 1.1-fold (0.02 log units) below what was measured, within the range that was stated.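

In the ADME assay, putting 4-(tert-butyl)phenoxy in place of pentan-3-yl gave a 14-fold higher number from compound 3 to compound 4 (1.14 log units; beyond the scatter), and this step matches the one seen earlier on the other side group: the same change on two cores in the ADME assay, a 14-fold higher number (1.14 log units; beyond the scatter) from compound 1 to compound 2 and a 14-fold higher number (1.14 log units; beyond the scatter) from compound 3 to compound 4, 1.0-fold (0.00 log units) apart, within the scatter of two such steps In the ADME assay, the swap to 2-hydroxy-3-methoxyphenyl from 5-fluoro-2-methoxyphenyl also gave the same result on both cores, with no change at the digits printed from compound 2 to compound 4 (within the scatter): the same change on two cores in the ADME assay, no change at the digits printed (within the scatter) from compound 1 to compound 3 and no change at the digits printed (within the scatter) from compound 2 to compound 4, 1.0-fold (0.00 log units) apart, within the scatter of two such steps These pairs show that the change carried over between these two side groups, but they do not show that it would carry over to any other core or why the number rises, and in a physicochemical assay for solubility, with a stated time of 18 h, at pH 7.4 (on this read-out lower numbers stand for lower solubility and higher numbers for higher solubility), the change is seen on a single pair, so nothing can be said there about carrying it over: the measured solubility of compound 3, 4200 nM, and of compound 4, 14500 nM, a 3.5-fold higher number (0.54 log units; beyond the scatter) In the physicochemical assay compound 3 gives 4200 nM and compound 4 gives 14500 nM.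

Going by these compounds, whether a similar step would appear with a plain phenoxy or a morpholine on that aromatic carbon remains open. Also open, on these data alone, is what a longer chain carrying the amine nitrogen would do to either read-out.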